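The source may report more compounds than this note shows. Statements on the series, on what has been measured and on what is new or still open speak of the compounds shown alone.

Working notes on the series.

Two compounds of this set have been run in a functional assay on cells (Cancer cell lines, Homo sapiens) for cytotoxicity, read by sulforhodamine B assay, with a stated time of 48 h; a higher number here means a weaker inhibitor of growth, a lower number a stronger inhibitor of growth. Compound 1, `COc1ccc(C2=NN(C3=NC(=O)/C(=C4\C(=O)Nc5ccccc54)S3)C(c3ccc(Cl)cc3)C2)cc1`, gives 100000 nM in this assay. Compound 2, `COc1ccc(-c2cc(-c3ccc(Cl)cc3)n(C3C(=O)Nc4ccc(Br)cc43)n2)cc1`, gives 16700 nM in this assay, the lower of the two numbers, and its gap to compound 1 lies beyond the scatter. Within the data shown here, the two compounds differ in more than one place, so no single step between them is drawn.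

The next compound, compound 3, `COc1ccc(-c2cc(-c3ccc(Cl)cc3)n(C3C(=O)Nc4ccc(Cl)cc43)n2)cc1`, differs from compound 2 by chloro in place of bromo on an aromatic carbon. Among the measured compounds shown here, no step between measured compounds of this kind is available here, so the size of the change is open. Since the exchanged group is a single halogen on the fused aromatic ring, the step from compound 2 to compound 3 is expected to be small, most likely no larger than the scatter, with no firm direction; the expectation is a 1.2-fold higher number from compound 2 to compound 3 (0.08 log units; within the scatter). On that basis compound 3 is estimated at 20000 nM in this assay, with a range from 8000 nM to 50000 nM.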

Compound 3, concentration for total growth inhibition: 14400 nM
For compound 3 the middle estimate is 1.4-fold (0.14 log units) above the measured one; the range from low to high includes it.
By their numbers in this assay, from the lowest: compounds 3 and 2 (each within the scatter of the next); then compound 1.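

In this assay, among these compounds, the exchange of bromo for chloro on this aromatic carbon gives a 1.2-fold lower number from compound 2 to compound 3 (0.06 log units; within the scatter), the first step that can be read at a single place. At this carbon of the fused system, meta to a fused ring and para to a fused ring, the assay does not tell the two halogens apart, so this one exchange gives no handle on the number. Nothing at hand accounts for this result.

From the compounds shown here alone, whether this carbon accepts a group other than a halogen, such as an amine, a nitrile or a carboxylic acid, remains open. Equally open, going by these compounds, is how the number would respond with hydrogen in place of the halogen at this carbon.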